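The source may hold more compounds than are shown below. What is called first, only, known or untested is meant among the compounds shown, and "the series" means these compounds.

Compound 3 `COc1cc(Cl)cc(-c2nn(-c3cccc(NC(=O)Nc4ccc(Cl)c(Cl)c4)c3)cc2-c2ccncc2)c1` in a functional assay on SNB-19 cells (Homo sapiens) for inhibition, read by sulforhodamine B assay, with a stated time of 48 h, tested at 0.01 uM (on this read-out lower numbers stand for a stronger effect and higher numbers for a weaker effect at the one concentration tested), gives 92%. Compound 2 `COc1cc(Cl)cc(-c2nn(-c3cccc(NC(=O)Nc4ccc(Cl)c(C(F)(F)F)c4)c3)cc2-c2ccncc2)c1` gives 92% and compound 1 `O=C(Nc1cccc(-n2cc(-c3ccncc3)c(-c3cc(O)cc(Cl)c3)n2)c1)Nc1ccc(Cl)c(Cl)c1` gives 97%, so compound 3 stands level with compound 2, the two together the lowest of the three numbers, and a number 5 percentage points lower from compound 1 to compound 3 (within the scatter) is the widest gap in the set, still within the scatter. Compound 4 `COc1cc(Cl)cc(-c2nn(-c3cccc(NC(=O)c4cccc(C(F)(F)F)c4)c3)cc2-c2ccncc2)c1` differs from compound 3 by 3-(trifluoromethyl)phenyl in place of (3,4-dichlorophenyl)amino on a carbonyl carbon. Neither measured step covers a change of this kind: a number 5 percentage points lower from compound 1 to compound 3 (within the scatter) concerns the methyl-for-hydrogen swap on the oxygen, and no change at the digits printed from compound 2 to compound 3 (within the scatter) the chloro-for-trifluoromethyl swap, both within the scatter. With all three numbers close together, no step beyond the scatter is expected, a number 1 percentage points higher from compound 3 to compound 4 (within the scatter). Compound 4 is therefore estimated at 93%, range 80% to 102%.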

Compound 4, a percentage reported as activity, at one concentration (the size of the read-out at that concentration, not a potency): 96%
Beside the measured number, compound 4's estimate is 3 percentage points below it, and the stated range covers the measured number.
By their numbers in this assay, from the lowest: compounds 2, 3, 4 and 1 (each within the scatter of the next).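

In this assay, the carbonyl carbon now has a measured change: 3-(trifluoromethyl)phenyl in place of (3,4-dichlorophenyl)amino gives a number 4 percentage points higher from compound 3 to compound 4 (within the scatter), and in place of (4-chloro-3-(trifluoromethyl)phenyl)amino it gives a number 4 percentage points higher from compound 2 to compound 4 (within the scatter). At this one concentration, the read-out therefore does not separate the aryl carbonyl from either arylamino group, even though the amide-type nitrogen's neighbour loses its hydrogen-bond donor. No evidence bearing on this result is available. From the compounds shown here alone, what a morpholine or a longer alkyl chain on that carbonyl carbon would give in this assay stays open, as does whether these steps hold at another concentration.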